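A second methoxy on compound 3

The source may hold more compounds than are shown below. What is called first, only, known or untested is meant among the compounds shown, and "the series" means these compounds.

In a functional assay on KB cells (Homo sapiens) for antiproliferative activity, read by sulforhodamine B assay, with a stated time of 72 h (on this read-out lower numbers stand for stronger inhibition and higher numbers for weaker inhibition), compound 1 (`O=C(/C=C/c1csc2ccccc12)c1ccccc1O`) gives 6200 nM, compound 2 (`O=C(/C=C/c1csc2ccccc12)c1cc(F)ccc1O`) gives 7400 nM and compound 3 (`COc1ccc(O)c(C(=O)/C=C/c2csc3ccccc23)c1`) gives 640 nM, the lowest of the three numbers. Compound 4 (`COc1cc(O)c(C(=O)/C=C/c2csc3ccccc23)cc1OC`) differs from compound 3 by one change: methoxy in place of hydrogen on an aromatic carbon. The new methoxy stands ortho to a methoxy group. For the measured compounds named here, the closest precedent is methoxy in place of hydrogen, a 9.7-fold lower number from compound 1 to compound 3 (0.99 log units; beyond the scatter), a modest step. Methoxy in place of fluoro gave a 12-fold lower number from compound 2 to compound 3 (1.06 log units; beyond the scatter), a large step, while fluoro in place of hydrogen gave a 1.2-fold higher number from compound 1 to compound 2 (0.08 log units; within the scatter). Going by the values given here, no measured step adds a second methoxy, so the earlier gain is not expected to repeat in full. The expected step is small: a 1.8-fold lower number from compound 3 to compound 4 (0.26 log units; within the scatter). Compound 4 is estimated at 350 nM, with a range of 90 nM to 1400 nM.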

Compound 4, half-maximal inhibitory concentration: 520 nM
The estimate for compound 4 lay 1.5-fold (0.17 log units) below the measured number; measured number inside the range.
By their numbers in this assay, from the lowest: compounds 4 and 3 (each within the scatter of the next); then compounds 1 and 2 (each within the scatter of the next).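

In this assay, methoxy in place of hydrogen on this aromatic carbon, ortho to a methoxy group and meta to a hydroxy group, gives a 1.2-fold lower number from compound 3 to compound 4 (0.09 log units; within the scatter). This position therefore accepts a second methoxy without a readable shift, whereas the first methoxy gave a 9.7-fold lower number from compound 1 to compound 3 (0.99 log units; beyond the scatter). The data shown offer no explanation for this difference between the two methoxy steps.

On these data alone, whether this position would respond to an amine, a carboxylic acid or a longer chain remains open. So does the effect of the new methoxy in the absence of the first one.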